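A few compounds are considered here, and "the series" means these few. Any claim that something is new, unique, unknown or untested is made for them only; others in the source may bear on it.

Compound 1 `Fc1ccccc1-c1ccc2[nH]ncc2c1` and compound 2 `CC(C)(C)c1ccccc1-c1ccc2[nH]ncc2c1` share one core and differ only in the group on an aromatic carbon. In an assay on CHO-TREX cells for antagonist activity at transient receptor potential cation channel subfamily A member 1 (Homo sapiens), read by FLIPR and calcium flux, with a stated time of 10 min (on this read-out higher numbers stand for weaker inhibition and lower numbers for stronger inhibition), compound 1 gives 3950 nM; compound 2 gives 3400 nM, and the two numbers lie within the scatter of each other. For the measured compounds named here, the single measured step, a 1.2-fold lower number from compound 1 to compound 2 (0.07 log units; within the scatter), is small. Compound 3 `FC(F)(F)c1ccccc1-c1ccc2[nH]ncc2c1` is not yet measured and differs from compound 1 as follows: trifluoromethyl in place of fluoro on an aromatic carbon. Going by the values given here, that step is the only guide, and it suggests little movement. Compound 3 is therefore expected to show a 1.1-fold lower number from compound 1 to compound 3 (0.05 log units; within the scatter). Compound 3 is estimated at 3500 nM, with a range from 1500 nM to 8500 nM.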

Compound 3, half-maximal inhibitory concentration: 164 nM
Compound 3: middle estimate off by 21-fold (1.33 log units), on the high side, outside the stated range (below it).
By their numbers in this assay, from the lowest: compound 3; then compounds 2 and 1 (each within the scatter of the next).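

In this assay trifluoromethyl at this position gives a 24-fold lower number from compound 1 to compound 3 (1.38 log units; beyond the scatter) and a 21-fold lower number from compound 2 to compound 3 (1.32 log units; beyond the scatter) even though fluoro and tert-butyl there gave numbers within the scatter of each other. The earlier small step therefore did not mean that this position tolerates any change without effect: the group placed here can matter a great deal. Nothing available explains why trifluoromethyl stands apart from the other two groups. From the compounds shown here alone, whether this large step is unique to trifluoromethyl stays open. The compounds shown do not tell how a chlorine atom, a methoxy group or an amine would read at this place.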